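Propyl in place of methoxy: working notes on the series

A few compounds are considered here, and "the series" means these few. Any claim that something is new, unique, unknown or untested is made for them only; others in the source may bear on it.

In a functional assay on HepG2 cells (Homo sapiens) for antiproliferative activity, read by CCK-8 assay, with a stated time of 72 h (a lower number here means a stronger inhibitor, a higher number a weaker inhibitor), compound 1 `CCc1ccc(OCc2ccc(C(=O)Nc3ccccc3N)cc2)cc1` gives 6960 nM and compound 2 `COc1ccc(OCc2ccc(C(=O)Nc3ccccc3N)cc2)cc1` gives 4200 nM. Going by the values given here, compound 2 therefore stands within the scatter of the only other measured compound. The next change leads to compound 3 `CCCc1ccc(OCc2ccc(C(=O)Nc3ccccc3N)cc2)cc1`: propyl in place of methoxy on an aromatic carbon, para to a large group. Among the compounds with values here, one measured step bears on it, a 1.7-fold lower number from compound 1 to compound 2 (0.22 log units; within the scatter), with ethyl and methoxy exchanged at this same place. That step lies within the scatter. Propyl has no measured precedent here, and the closest measured group is the ethyl of compound 1, at 6960 nM. No step beyond the scatter is therefore expected in this assay, and any drift is expected towards a higher number. The estimated step is a 1.7-fold higher number from compound 2 to compound 3 (0.22 log units; within the scatter). For compound 3 the expected value is 7000 nM, with an estimated range of 3000 nM to 16000 nM.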

Compound 3, half-maximal inhibitory concentration: 4750 nM
Compound 3: middle estimate off by 1.5-fold (0.17 log units), on the high side, and the stated range covers the measured number.
By their numbers in this assay, from the lowest: compounds 2, 3 and 1 (each within the scatter of the next).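

In this assay, propyl in place of methoxy gives a 1.1-fold higher number from compound 2 to compound 3 (0.05 log units; within the scatter) at this place, on an aromatic carbon para to a large group, so removing the one hydrogen-bond acceptor counted in methoxy brings no step beyond the scatter. Methyl in place of hydrogen on a saturated chain carbon, two bonds along the chain from an aromatic carbon, gives a 1.5-fold lower number from compound 1 to compound 3 (0.17 log units; within the scatter) and so extending ethyl to propyl also brings no step beyond the scatter. Nothing measured on these compounds explains this flat reading at the position.

Open, as far as these compounds go, is whether a longer chain such as butyl would keep the number within the scatter. Also open is whether an amine or a carboxylic acid at this place, where all groups shown carry no net charge, would give a step beyond it.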